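Amide-Tail Variation on a Spiro Core: Predicting Compound 4

The source may report more compounds than this note shows. Statements on the series, on what has been measured and on what is new or still open speak of the compounds shown alone.

Measured so far in an assay on HEK293 cells for displacement of a labelled ligand from NPC1-like intracellular cholesterol transporter 1 (Homo sapiens); on this read-out lower numbers stand for stronger inhibition and higher numbers for weaker inhibition:
- compound 1, `CC(C)(C)OC(=O)NCCCCCNC(=O)CN1CN(c2ccccc2)C2(CCN(C(=O)c3ccc(C(C)(C)C)cc3)CC2)C1=O`, 13700 nM
- compound 2, `CC(C)(C)c1ccc(C(=O)N2CCC3(CC2)C(=O)N(CC(=O)NCCN)CN3c2ccccc2)cc1`, 7000 nM
- compound 3, `CC(C)(C)c1ccc(C(=O)N2CCC3(CC2)C(=O)N(CC(=O)N2CCCC(CO)C2)CN3c2ccccc2)cc1`, 8200 nM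

The three compounds share one core and differ only in the group attached to a carbonyl carbon at the end of a short chain. On the numbers shown, compound 3 stands second highest of the three; its nearest neighbour is compound 2 and its furthest is compound 1, and both gaps are within the scatter.

Compound 4, `CC(C)(C)c1ccc(C(=O)N2CCC3(CC2)C(=O)N(CC(=O)NCCCCNS(C)(=O)=O)CN3c2ccccc2)cc1`, is not yet measured. It differs from compound 3 in one place: (4-(methanesulfonamido)butyl)amino in place of 3-(hydroxymethyl)piperidin-1-yl on a carbonyl carbon.

Within the data shown here, two measured steps bear on this position. The step of a 2.0-fold lower number from compound 1 to compound 2 (0.29 log units; within the scatter) and the step of a 1.2-fold higher number from compound 2 to compound 3 (0.07 log units; within the scatter) both changed the group on the same carbonyl carbon, and neither moved the number beyond the scatter. Among the measured compounds shown here, nothing among the measured compounds suggests that this position governs the read-out. The expected step is therefore a 1.1-fold higher number from compound 3 to compound 4 (0.04 log units; within the scatter) in this assay, no real direction beyond the scatter.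

Compound 4 is estimated at 9000 nM in this assay, with a likely range from 4000 nM to 20000 nM.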

Compound 4, half-maximal inhibitory concentration: 4500 nM
Compound 4: the middle estimate sits 2.0-fold (0.30 log units) above what was measured; low and high end bracket the measured number.
By their numbers in this assay, from the lowest: compounds 4, 2, 3 and 1 (each within the scatter of the next, the first and the last beyond it).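

In this assay, replacing the ring-bearing tail with an open chain ending in methanesulfonamido gives a 1.8-fold lower number from compound 3 to compound 4 (0.26 log units; within the scatter), so this carbonyl carbon accepts a tail with no ring and a sulfonamide at its far end without a real change in the number. Measured against the tail ending in a free amine, the same group gives a 1.6-fold lower number from compound 2 to compound 4 (0.19 log units; within the scatter), again within the scatter, whereas measured against the tail capped with tert-butoxycarbonyl it gives a 3.0-fold lower number from compound 1 to compound 4 (0.48 log units; beyond the scatter), a modest step and the only one among these compounds to pass beyond the scatter. The position can therefore move the number a little, though no measurement here bears on why it does.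

Between compound 1 and compound 4, the chain length and the end group change together, so their contributions cannot be separated. The compounds shown also leave open what a methanesulfonamido group would do on a longer or shorter chain, and whether a carboxylic acid at the end of the butyl chain would behave like the sulfonamide or the free amine.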